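A trifluoromethyl step starting from a limit

The compounds below may be only part of what the source reports. "The series", "measured", "known", "first", "only" and "open" are said of these compounds alone.

In an ADME assay on MDBK cells (Bos taurus) for cytotoxicity, read by MTT assay, with a stated time of 96 h (on this read-out higher numbers stand for lower toxicity in this test and lower numbers for higher toxicity in this test), compound 1 `CC(=O)c1ccc2[nH]c(-c3ccccc3)nc2c1` gives > 100000 nM as a limit of the assay. Compound 2 `COc1ccc(-c2nc3cc(/C(C)=N/NC(N)=O)ccc3[nH]2)c(OC)c1` gives > 100000 nM as a limit as well. Compound 3 `CC(=O)c1ccc2c(c1)nc(-c1ccccc1)n2C1CCCCC1` gives > 100000 nM as a limit too, so its standing is known only as a limit and not as a number.

Compound 4 `CC(=O)c1ccc2c(c1)nc(-c1ccc(C(F)(F)F)cc1)n2C1CCCCC1` differs from compound 3 by a single change trifluoromethyl in place of hydrogen on an aromatic carbon and so carries trifluoromethyl in place of hydrogen on an aromatic carbon. Among the measured compounds shown here, the only measured step is a step that the two limits leave unreadable from compound 1 to compound 3 and it lies at another place in the molecule, so it offers no size to carry over. All three measured compounds sit at the limit of > 100000 nM in this assay, at which 3 of the 3 values shown sit, and no number yet anchors a step in this assay in either direction. At most a small move towards lower numbers is expected, and quite possibly none that can be read. The expected change is an at least 1.1-fold lower number from compound 3 to compound 4 (0.04 log units; that floor lies within the scatter) in this estimate. For compound 4 the estimated value is 90000 nM with an expected range from 40000 nM to 100000 nM as the likely span.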

Compound 4, half-maximal cytotoxic concentration: 52000 nM
Estimate against measurement, compound 4: 1.7-fold (0.24 log units) above; low and high end bracket the measured number.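

In this assay, trifluoromethyl in place of hydrogen on an aromatic carbon, para to a large group, gives an at least 1.9-fold lower number from compound 3 to compound 4 (0.28 log units; that floor lies within the scatter), the only step shown with a readable direction, though its floor lies within the usual scatter. This position is thus the one place among those shown where a change yields a lower number in this test. Compound 4 is also the only compound shown that gives a number rather than a limit: the limit of > 100000 nM in this assay, at which 3 of the 4 values shown sit.

As far as these compounds go, the true size of the step stays open, since compound 3 has only a limit, and so does whether the step is particular to trifluoromethyl rather than shared by a nitrile or an amine at that place. From the compounds shown here alone, the step that places cyclohexyl on the aromatic nitrogen cannot be read, so what that group contributes also remains open.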